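Homologation of the propyl chain: expectation for compound 4

This account rests on a few compounds, and the source may have more. Where it says the series, first, only, none or still open, it means among the compounds named here.

For the measured compounds named here, compound 1 `CCCc1ccc2c(c1)sc(=O)n2CCN1CCCCC1` gives 0.6 nM in an assay on membranes from brain for displacement of a labelled ligand from Sigma non-opioid intracellular receptor 1 (Cavia porcellus) (on this read-out lower numbers stand for stronger inhibition and higher numbers for weaker inhibition), the second highest of the three numbers so far. Compound 3 `CCCc1ccc2c(c1)sc(=O)n2CCN1CCCCCC1` gives 0.56 nM; the step of a 1.1-fold lower number from compound 1 to compound 3 (0.03 log units; within the scatter) stays within the scatter. Compound 2 `CCC(=O)c1ccc2c(c1)sc(=O)n2CCCN1CCCCC1` gives 2.3 nM; it differs from compound 1 in two places at once, so its higher number cannot be tied to either change alone.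

Compound 4 `CCCCc1ccc2c(c1)sc(=O)n2CCN1CCCCC1` is not yet measured. It differs from compound 1 by methyl in place of hydrogen on a saturated chain carbon, three bonds along the chain from an aromatic carbon. Going by the values given here, no measured step in this set changes the chain on the aromatic carbon, so there is no direct precedent for this homologation. Among the compounds with values here, the only single-point step available, a 1.1-fold lower number from compound 1 to compound 3 (0.03 log units; within the scatter), was within the scatter, and a one-carbon extension of a saturated chain is the kind of change that often leaves this read-out little moved. The step from compound 1 to compound 4 is therefore expected to be small, a 1.2-fold higher number from compound 1 to compound 4 (0.07 log units; within the scatter), in no firm direction. Compound 4 is estimated at 0.7 nM, within a range from 0.25 nM to 2 nM.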

Compound 4, inhibition constant: 3.7 nM
For compound 4 the middle estimate is 5.3-fold (0.72 log units) below the measured one, outside the stated range (above it).
By their numbers in this assay, from the lowest: compounds 3 and 1 (each within the scatter of the next); then compounds 2 and 4 (each within the scatter of the next).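

In this assay the saturated chain on the aromatic carbon proves sensitive to one added carbon: propyl to butyl gives a 6.2-fold higher number from compound 1 to compound 4 (0.79 log units; beyond the scatter) and this is the only listed step that lies beyond the scatter. For the compounds shown here, the one earlier single-place step, a 1.1-fold lower number from compound 1 to compound 3 (0.03 log units; within the scatter) with azepan-1-yl in place of piperidin-1-yl, lay within the scatter, so this chain position now reads as the more responsive of the two places changed so far. No measurement at hand accounts for the rise in the number.

From the compounds shown here alone, a single step fixes no trend along this chain, and whether ethyl or pentyl at the same position would follow the direction of this step remains open. Also open, going by these compounds, is whether butyl gives a step of similar size on the azepan-1-yl compound 3, and whether a branched chain such as isobutyl reads like butyl.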